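The compounds below may be only part of what the source reports. "The series", "measured", "known", "first", "only" and "open" are said of these compounds alone.

In a functional assay on MCF7 cells (Homo sapiens) for antiproliferative activity, read by sulforhodamine B assay, with a stated time of 48 h (a lower number here means a stronger inhibitor of growth, a higher number a weaker inhibitor of growth), compound 1 `COc1ccc(Cn2cc(CNC(=O)c3cn(-c4ccccc4)nc3-c3ccccc3)nn2)cc1` gives > 100000 nM, a limit and not a number. Within the data shown here, compound 2 `COc1cc(Cn2cc(CNC(=O)c3cn(-c4ccccc4)nc3-c3ccccc3)nn2)cc(OC)c1` gives 2400 nM, the only true number so far. Compound 3 `COc1cc(Cn2cc(CNC(=O)c3cn(-c4ccccc4)nc3-c3ccccc3)nn2)cc(OC)c1OC` gives > 100000 nM, also a limit and not a number. This places compound 3 at the limit of > 100000 nM in this assay, at which 2 of the 3 values shown sit.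

Compound 4 `COc1cc(Cn2cc(CNC(=O)c3cn(-c4ccccc4)nc3-c3ccc(Cl)cc3)nn2)cc(OC)c1OC` differs from compound 3 by chloro in place of hydrogen on an aromatic carbon, phenyl to 4-chlorophenyl, para to a large group: chloro in place of hydrogen on an aromatic carbon.

Among the measured compounds shown here, none of the measured steps touches that phenyl. All three change the methoxy pattern on the other aromatic group. Having 3,5-dimethoxyphenyl in place of 4-methoxyphenyl gives an at least 41-fold lower number from compound 1 to compound 2 (1.61 log units; beyond the scatter). Methoxy in place of hydrogen on an aromatic carbon gives an at least 41-fold higher number from compound 2 to compound 3 (1.61 log units; beyond the scatter), the closest measured parallel in kind, though at a different place. The third step reads a step that the two limits leave unreadable from compound 1 to compound 3.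

These steps show that one added group can shift this series strongly, so a sizeable change is possible in this assay. Only a move toward a lower number could be read, and compound 4 may also remain at the limit. The estimated step is an at least 3.3-fold lower number from compound 3 to compound 4 (0.52 log units; beyond the scatter). Compound 4 is expected at about 30000 nM, with an estimated range of 2000 nM to 100000 nM.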

Compound 4, concentration for 50% growth inhibition: 2500 nM
Estimate against measurement, compound 4: 12-fold (1.08 log units) above; low and high end bracket the measured number.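

In this assay, the phenyl that becomes 4-chlorophenyl turns out to be a second place that moves this series: chloro in place of hydrogen gives an at least 40-fold lower number from compound 3 to compound 4 (1.60 log units; beyond the scatter), whereas every earlier step changed only the methoxy pattern on the other aromatic group. The 3,4,5-trimethoxyphenyl group therefore does not by itself hold a compound at the limit, as compound 4 carries that group and still gives a true number. Compound 3 sits at a limit and not a number, so the full size of this step stays unknown, its starting point being: the limit of > 100000 nM in this assay, at which 2 of the 4 values shown sit.

It remains open whether chloro on this phenyl would shift the number in the same direction and to a similar extent with the 3,5-dimethoxyphenyl or 4-methoxyphenyl group in place, since only one such pair is shown. Going by these compounds, it is also open whether the effect is specific to chloro or would appear with another group at the same place, such as fluoro, methyl, an amine or a carboxylic acid, and these values alone assign no cause to the change.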